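The source may report more compounds than this note shows. Statements on the series, on what has been measured and on what is new or still open speak of the compounds shown alone.

Compound 3, `Cc1cc(C)cc(S(=O)(=O)c2c(C(=O)NCc3n[nH]c4ccccc34)[nH]c3ccc(Cl)cc23)c1`, was tested in an ADME assay on MT4 cells (Homo sapiens) for cytotoxicity, read by MTT assay (a lower number here means that less compound is tolerated, a higher number that more compound is tolerated), where it gave only a limit of the assay, > 50700 nM, and no number. Compound 2, `Cc1cc(C)cc(S(=O)(=O)c2c(C(=O)NC(c3ccc(Cl)cc3)C3CC3)[nH]c3ccc(Cl)cc23)c1`, likewise reached only a limit in this assay, > 47300 nM. Compound 1, `Cc1cc(C)cc(S(=O)(=O)c2c(C(=O)NC(C)C(=O)NCc3ccccc3F)[nH]c3ccc(Cl)cc23)c1`, is the one of the three that yields a number in this assay, 23300 nM. Among the values shown, compound 3 therefore stands at a limit, and one of the two other values is a limit as well. For the measured compounds named here, the single step that joins compound 3 to a measured neighbour is a step that the two limits leave unreadable from compound 2 to compound 3; it cannot be read because the limit of > 47300 nM in this assay, at which 1 of the 3 values shown sits, and the limit of > 50700 nM in this assay, at which 1 of the 3 values shown sits, both cap the values. Compound 4, `Cc1cc(C)cc(S(=O)(=O)c2c(C(=O)NC(C)C(=O)NCc3ccco3)[nH]c3ccc(Cl)cc23)c1`, carries a change on the same amide-type nitrogen: 1-(((furan-2-yl)methyl)carbamoyl)ethyl in place of (1H-indazol-3-yl)methyl on an amide-type nitrogen. Going by the values given here, no measured step covers this exchange, so its size in this assay cannot be taken from compound 2 or compound 3. Compound 4 has on that nitrogen a chain closer to that of compound 1, which gives 23300 nM. Compound 4 is therefore expected near that value, at 30000 nM, with a range from 12000 nM to 60000 nM. Against the limit of compound 3 this would be an estimated step of an at least 1.6-fold lower number from compound 3 to compound 4 (0.22 log units; that floor lies within the scatter), whose direction the limit leaves open.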

Compound 4, half-maximal cytotoxic concentration: 24200 nM
The estimate for compound 4 lay 1.2-fold (0.09 log units) above the measured number, and the stated range covers the measured number.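

Measured in this assay, the exchange on the amide-type nitrogen now has a direction that the earlier limits could not give, with an at least 2.0-fold lower number from compound 3 to compound 4 (0.32 log units; beyond the scatter); the value for compound 3 is only a limit of the assay, so this size is a floor. The value for compound 2 is also only a limit, and the comparison with it gives an at least 1.9-fold lower number from compound 2 to compound 4 (0.29 log units; that floor lies within the scatter), so this floor does not by itself establish a real difference. The change at the far end of the chain gives a 1.0-fold higher number from compound 1 to compound 4 (0.02 log units; within the scatter), so furan-2-yl and 2-fluorophenyl cannot be told apart in this assay, and among these four compounds the two that carry this carbamoyl-bearing chain give numbers, while the two without it stay at limits.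

On these data alone, the true sizes of the two steps that start from limits remain open, as does which part of the chain matters for the lower number. Also open, as far as these compounds go, is whether an aliphatic amine or a carboxylic acid in place of furan-2-yl would give a number apart from those of compound 1 and compound 4.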